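Methyl for fluoro on two related cores

The source may report more compounds than this note shows. Statements on the series, on what has been measured and on what is new or still open speak of the compounds shown alone.

Compound 1 `Cc1cccc(-c2n[nH]cc2N2CCCNCC2)c1` and compound 2 `Fc1cccc(-c2n[nH]cc2N2CCCNCC2)c1` share one core and differ only at the aryl substituent. In an assay on isolated protein for binding affinity to 5-hydroxytryptamine receptor 1D (Homo sapiens) (a lower number here means a stronger inhibitor, a higher number a weaker inhibitor), compound 2 gives 2540 nM. In this assay compound 1 gives 3290 nM. The step between them, (methyl in place of fluoro on an aromatic carbon), amounts to a 1.3-fold higher number from compound 2 to compound 1 (0.11 log units; within the scatter), so the two values cannot be told apart.

Compound 3 `Fc1ccc(-c2n[nH]cc2N2CCNCC2)cc1` carries a different core; the difference between the two cores is not broken down here. In this assay compound 3 reaches only a limit, > 10000 nM, and no number is given, which is recorded as the limit of > 10000 nM in this assay, at which 1 of the 3 values shown sits.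

Compound 4 `Cc1ccc(-c2n[nH]cc2N2CCNCC2)cc1`, not yet measured, repeats the same kind of change on the core of compound 3: methyl in place of fluoro on an aromatic carbon. The change is the same kind as that from compound 2 to compound 1, but the place differs: in the measured pair the group stands meta to a large group, in compound 4 it stands para to a large group. Among the compounds shown this change occurs two times in all.

Because the measured instance of this change gave a 1.3-fold higher number from compound 2 to compound 1 (0.11 log units; within the scatter), the expected step here is a step that the limit leaves unreadable from compound 3 to compound 4, and because compound 3 sits at the limit of > 10000 nM in this assay, at which 1 of the 3 values shown sits, the most likely outcome for compound 4 is again a limit. The estimate for compound 4 in this assay is 15000 nM, expected within 5000 nM to 50000 nM.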

Compound 4, inhibition constant: 325 nM
Compound 4: middle estimate off by 46-fold (1.66 log units), on the high side; measured number outside the range, below it.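

Methyl in place of fluoro on an aromatic carbon, para to a large group, gives an at least 30-fold lower number from compound 3 to compound 4 (1.48 log units; beyond the scatter) in this assay and marks this as a large step in the series. The size of the step measured on one core therefore does not predict its size on the other core among the compounds shown: the same change on two cores in this assay, a 1.3-fold higher number (0.11 log units; within the scatter) from compound 2 to compound 1 and an at least 30-fold lower number (1.48 log units; beyond the scatter) from compound 3 to compound 4, at least 39-fold (1.60 log units) apart, beyond the scatter of two such steps

Within the data shown here, the two pairs differ both in the core and in the place of the group on the aromatic ring, so these data do not show which of the two differences goes with the gap, and with only two pairs they set no rule for other cores.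

Compound 3 has only a limit of > 10000 nM and not a number, which leaves the full size of the step open. Also open, on these data alone, is how methyl and fluoro compare para to a large group on the core of compound 1, and how a chloro or methoxy group in that same place would read on the core of compound 4.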